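Acetyl to methylsulfonyl on the amine of compound 1

This account rests on a few compounds, and the source may have more. Where it says the series, first, only, none or still open, it means among the compounds named here.

Measured so far:
compound 1, `CC(=O)N[C@@H]1CCCc2c1cncc2N1CCc2cc(Cl)ccc2C1=O`: 54 nM
compound 2, `Cc1cccnc1C(=O)NCc1cncc(N2C(=O)c3ccc(Cl)cc3C2(C)C)c1`: 9 nM
compound 3, `CCS(=O)(=O)N1CC(Oc2cncc(N3C(=O)c4ccc(Cl)cc4C3(C)C)c2)C1`: 4 nM

In an assay on cells for inhibition of cytochrome P450 11B2, mitochondrial (Homo sapiens), read by HTRF (on this read-out higher numbers stand for weaker inhibition and lower numbers for stronger inhibition), compound 1 gives the highest number of the three. Compound 2 stands lower, and compound 3 lower still, and both of those gaps to compound 1 lie beyond the scatter. For the measured compounds named here, compound 2 and compound 3 are built on a different core from compound 1, and no pair among the three differs in a single place, so the measured set offers no step that isolates a change on the amine nitrogen of compound 1.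

Going by the values given here, compound 4, `CS(=O)(=O)N[C@@H]1CCCc2c1cncc2N1CCc2cc(Cl)ccc2C1=O`, is the first such single-point change: methylsulfonyl in place of acetyl on an amine nitrogen, the same difference reading acetamido to methanesulfonamido one bond further out. Among the compounds with values here, with no matched pair to lean on, the expectation is a small move, most likely not beyond the scatter, with a slight lean toward a lower number.

Compound 4 is therefore estimated at 40 nM in this assay, with a range of 15 nM to 120 nM. The step this estimate implies, a 1.4-fold lower number from compound 1 to compound 4 (0.13 log units; within the scatter), is expected to remain within the scatter.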

Compound 4, half-maximal inhibitory concentration: 76 nM
Compound 4: middle estimate off by 1.9-fold (0.28 log units), on the low side; measured number inside the range.
By their numbers in this assay, from the lowest: compound 3; then compound 2; then compounds 1 and 4 (each within the scatter of the next).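

In this assay, this first matched pair on the amine nitrogen gives a 1.4-fold higher number from compound 1 to compound 4 (0.15 log units; within the scatter), a step that stays within the usual scatter, so acetyl and methylsulfonyl cannot be told apart at this position on the core of compound 1. Here, replacing acetyl, with 1 hydrogen-bond acceptor and 1 double bond outside aromatic rings, by methylsulfonyl, with 2 of each, leaves the read-out without a separable change; this is a single pair and sets no trend for the series. No measurement available here bears on why the two groups read alike, so the result stands as an observation only.

Going by these compounds, it remains open whether a different kind of group on this nitrogen, such as a longer acyl chain like butanoyl, a carboxylic acid or a free amine, would move the number beyond the scatter. On these data alone, it is also open whether exchanging acetyl for methylsulfonyl would give a similarly small step on the different core shared by compound 2 and compound 3.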